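The compounds below may be only part of what the source reports. "The series", "measured", "known", "first", "only" and "open" are said of these compounds alone.

Three compounds were measured in a functional assay on RAW264.7 cells (Mus musculus) for inhibition, read by Griess assay, with stated times of 1 h and 24 h (on this read-out lower numbers stand for stronger inhibition and higher numbers for weaker inhibition), and gave these values:
Compound 1 `CCCCCCOc1ccc(C(O)C2OC(=O)c3c(OC)cc(OC)cc32)cc1` gives 5360 nM
Compound 2 `COCCCOc1ccc(C(O)C2OC(=O)c3c(OC)cc(OC)cc32)cc1` gives 1260 nM
Compound 3 `COc1cc(OC)c2c(c1)C(C(O)c1ccc(OCc3ccc(F)cc3)cc1)OC2=O` gives 760 nM

Compound 3 stands level with its nearest neighbour, the measurements showing a 1.7-fold lower number from compound 2 to compound 3 (0.22 log units; within the scatter), and clear of the furthest, with a 7.1-fold lower number from compound 1 to compound 3 (0.85 log units; beyond the scatter). In compound 4 `COc1cc(OC)c2c(c1)C(C(O)c1ccc(OCc3ccc(Br)cc3)cc1)OC2=O` the change is bromo in place of fluoro on an aromatic carbon, which is bromo in place of fluoro on an aromatic carbon, para to a large group. Among the compounds with values here, no measured step alters this halogen. Within the data shown here, the steps that bear on it do so only indirectly, since they exchange the whole group on the oxygen. Even those exchanges stayed modest in this assay, giving a 1.7-fold lower number from compound 2 to compound 3 (0.22 log units; within the scatter) and a 7.1-fold lower number from compound 1 to compound 3 (0.85 log units; beyond the scatter), so a single halogen swap is expected to produce no shift beyond the scatter. The expected outcome is a 1.1-fold lower number from compound 3 to compound 4 (0.04 log units; within the scatter), a step that would leave the two compounds level. For compound 4 the estimated value is 700 nM, with an expected range from 300 nM to 1600 nM.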

Compound 4, half-maximal inhibitory concentration: 6530 nM
Compound 4: middle estimate off by 9.3-fold (0.97 log units), on the low side; the whole stated range lies below it.
By their numbers in this assay, from the lowest: compounds 3 and 2 (each within the scatter of the next); then compounds 1 and 4 (each within the scatter of the next).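

In this assay, bromo in place of fluoro on an aromatic carbon, para to a large group, gave a clear step (an 8.6-fold higher number from compound 3 to compound 4 (0.93 log units; beyond the scatter)), so this position is sensitive to the identity of its halogen. An aromatic group on the oxygen does not by itself carry the lower number: 4-bromobenzyl stands clearly apart from the 3-methoxypropyl chain (a 5.2-fold higher number from compound 2 to compound 4 (0.71 log units; beyond the scatter)) but level with the hexyl chain (a 1.2-fold higher number from compound 1 to compound 4 (0.09 log units; within the scatter)), whereas 4-fluorobenzyl stood clear of hexyl. No available evidence accounts for this halogen effect.

From the compounds shown here alone, it remains open whether chloro or hydrogen at this place would align with fluoro or with bromo. Whether a methoxy group or an amine there would hold the number of compound 3 is also unresolved.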